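This account rests on a few compounds, and the source may have more. Where it says the series, first, only, none or still open, it means among the compounds named here.

Measured so far:
- compound 1, `CCc1cc(C(C)=O)c(O)cc1OCCCC(C)(C)C#N`: 46%
- compound 2, `CCc1cc(C(C)=O)c(O)cc1OCCCCCC(C)(C)C(=O)O`: 73%

In an assay on isolated protein for binding affinity to leukotriene B4 receptor 1 (Homo sapiens), tested at 1 uM (a higher number here means more inhibition at the concentration tested (going by the name of the read-out), a lower number less inhibition), compound 2 stands highest of the two numbers; its nearest neighbour, compound 1, sits a number 27 percentage points higher from compound 1 to compound 2 (beyond the scatter) away. Compound 3, `CCc1cc(C(C)=O)c(O)cc1OCCCC(C)(C)C(N)=O`, is not yet measured. It differs from compound 2 by 1-carbamoyl-1-methylethyl in place of 3-carboxy-3-methylbutyl on a saturated chain carbon, three bonds along the chain from an oxygen on an aromatic ring. For the measured compounds named here, the one step that bears on it is the rise of a number 27 percentage points higher from compound 1 to compound 2 (beyond the scatter), which accompanied the longer carboxy-bearing chain. Compound 3 returns to the shorter chain length of compound 1 but carries a carbamoyl rather than a nitrile, so part of that rise is expected to be lost. The expected step is a number 21 percentage points lower from compound 2 to compound 3 (beyond the scatter). Compound 3 is estimated at 52%, within 32% to 72% in this assay.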

Compound 3, a percentage reported as inhibition, at one concentration (the size of the read-out at that concentration, not a potency): 51%
Compound 3: the middle estimate sits 1 percentage points above what was measured; the measured number falls inside the stated range.
By their numbers in this assay, from the lowest: compounds 1 and 3 (each within the scatter of the next); then compound 2.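

In this assay, carbamoyl in place of cyano on a saturated chain carbon bound to three saturated chain carbons gives a number 5 percentage points higher from compound 1 to compound 3 (within the scatter) and so does not separate the two chain ends. Compound 2 stays apart, with a number 22 percentage points lower from compound 2 to compound 3 (beyond the scatter) for a change that alters chain length and end group together. No measurement on hand gives a reason for either step.
Open, as far as these compounds go, is whether a carboxylic acid on the shorter chain of compound 1 would reach the level of compound 2, or whether the longer chain ending in a nitrile or carbamoyl would.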